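A few compounds are considered here, and "the series" means these few. Any claim that something is new, unique, unknown or untested is made for them only; others in the source may bear on it.

Compound 2 `CCCCCN(CCCCC)S(=O)(=O)NC(=O)Oc1c(C(C)(C)C)cc(C)cc1C(C)(C)C` gives 2200 nM in an assay on liver for inhibition of sterol O-acyltransferase 1 (Rattus norvegicus), using microsomes (on this read-out higher numbers stand for weaker inhibition and lower numbers for stronger inhibition), the lower of the two numbers recorded. Compound 1 `CCCCN(CCCC)S(=O)(=O)NC(=O)Oc1c(C(C)(C)C)cc(C)cc1C(C)(C)C` gives 3200 nM in this assay, and the step of a 1.5-fold lower number from compound 1 to compound 2 (0.16 log units; within the scatter) lies within the scatter. Compound 3 `CCCCCCOS(=O)(=O)NC(=O)Oc1c(C(C)(C)C)cc(C)cc1C(C)(C)C` carries hexyloxy in place of dipentylamino on a sulfonyl sulfur. Among the compounds with values here, the only measured step alters the chain length on the nitrogen rather than the kind of atom attached to the sulfonyl sulfur, so no measured step bears directly on this change, and the direction is open. Compound 3 is therefore expected to give 4000 nM, with a range from 1000 nM to 16000 nM. For compound 3 this means an expected step of a 1.8-fold higher number from compound 2 to compound 3 (0.26 log units; within the scatter), possibly none beyond the scatter.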

Compound 3, half-maximal inhibitory concentration: 95000 nM
Estimate against measurement, compound 3: 24-fold (1.38 log units) below, and the stated range ends below it.
By their numbers in this assay, from the lowest: compounds 2 and 1 (each within the scatter of the next); then compound 3.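

In this assay, the sulfonyl sulfur proves sensitive to what is attached to it: hexyloxy in place of dipentylamino gives a 43-fold higher number from compound 2 to compound 3 (1.64 log units; beyond the scatter), and hexyloxy in place of dibutylamino gives a 30-fold higher number from compound 1 to compound 3 (1.47 log units; beyond the scatter). Within the data shown here, the earlier change of chain length on nitrogen stayed within the scatter, so this is the first large step seen at this position. Nothing given here accounts for this weakening. The change replaces two chains on nitrogen with one chain on oxygen, so the compounds shown cannot separate those two differences. Going by these compounds, whether a single hexylamino group on the sulfonyl sulfur would read like compound 2 or like compound 3 remains open.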